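Adding a Methyl Where Every Compound So Far Sits Flat

The compounds below may be only part of what the source reports. "The series", "measured", "known", "first", "only" and "open" are said of these compounds alone.

Of the compounds shown here, three have been tested in a functional assay on the whole organism (strain Swiss) with Mus musculus as the target, in the maximal electroshock model, with a stated time of 2 h, at a dose of 300 mg/kg by the intraperitoneal route; on this read-out higher numbers stand for a stronger effect at the one dose given and lower numbers for a weaker effect. Compound 1 `CCC(C(=O)N1CCN(c2ccccc2Cl)CC1)N1C(=O)CCC1=O` gives 0% in this assay, and compound 2 `CCC(C(=O)N1CCN(c2ccc(F)cc2)CC1)N1C(=O)CCC1=O` gives 0%; the step of no change at the digits printed from compound 1 to compound 2 (within the scatter) shows nothing beyond the scatter. Compound 3 `CC(C(=O)N1CCOCC1)N1C(=O)CCC1=O`, built on a different core, gives 0% in this assay and therefore stands level with compound 1 and compound 2 at the digits shown, with no measured compound departing from this common level.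

Compound 4 `CCC(C(=O)N1CCOCC1)N1C(=O)CCC1=O` has not yet been measured. It differs from compound 3 by methyl in place of hydrogen on a saturated chain carbon, two bonds along the chain from an amide-type nitrogen in a ring and a carbonyl carbon; the same difference, cut one bond further out, reads methyl to ethyl. Among the measured compounds shown here, no measured step alters this position on its own. For the measured compounds named here, the only measured step, from compound 1 to compound 2, concerns the group on an amine nitrogen in a ring and bears on the present change only indirectly: it shows that compound 1 and compound 2, both carrying the longer chain, sit at the same level as compound 3 in this assay. With nothing in the measured set moving this assay beyond the scatter, the step is expected to be no change at the digits printed from compound 3 to compound 4 (within the scatter), within the scatter. Compound 4 is therefore estimated at 0%, with an expected range from 0% to 10%.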

Compound 4, a percentage reported as activity, at one dose (the size of the read-out at that dose, not a potency): 0%
For compound 4 middle estimate and measured number coincide at the digits printed; measured number inside the range.
By their numbers in this assay, from the lowest: compounds 1, 2, 3 and 4 (each within the scatter of the next).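

In this assay, methyl in place of hydrogen on a saturated chain carbon, two bonds along the chain from an amide-type nitrogen in a ring and a carbonyl carbon, now has a reading of its own: no change at the digits printed from compound 3 to compound 4 (within the scatter) at this one dose. Among the compounds shown here, the only earlier step concerned the group on an amine nitrogen in a ring, so this is the first result to speak to this position directly, and it shows that the added methyl brings no detectable effect on the core of compound 3. Since compound 3 already gives 0% and a lower reading cannot be seen from there, the step shows only that no effect is gained, not that the position tolerates the change; no outside evidence bears on this result.

The compounds shown leave open whether a longer chain such as propyl, a phenyl ring, an amine or a carboxylic acid on this same carbon would give a reading above that common level. They also leave open whether the methyl step would read the same on a core that shows an effect at all, since none of the compounds here departs from that level.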